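Sulfamoyl to sulfo on the side chain

The source may hold more compounds than are shown below. What is called first, only, known or untested is meant among the compounds shown, and "the series" means these compounds.

In a functional assay on the whole organism with Rattus norvegicus as the target (a higher number here means that more compound is needed for the effect, a lower number that less compound is needed), compound 1 `C=CCn1c(=N)sc2cc(OC(F)(F)F)ccc21` gives 7 mg/kg. Compound 3 `N=c1sc2cc(OC(F)(F)F)ccc2n1CCS(N)(=O)=O` gives 6 mg/kg, within the scatter of compound 1. Compound 2 `COC(=O)Cn1c(=N)sc2cc(OC(F)(F)F)ccc21` reaches only a limit of the assay, > 10 mg/kg.

Compound 4 `N=c1sc2cc(OC(F)(F)F)ccc2n1CCS(=O)(=O)O` carries hydroxy in place of amino on a sulfonyl sulfur, turning 2-sulfamoylethyl into 2-sulfoethyl (hydroxy in place of amino on a sulfonyl sulfur).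

Three measured steps alter the same side chain: a 1.2-fold lower number from compound 1 to compound 3 (0.07 log units; within the scatter), an at least 1.4-fold higher number from compound 1 to compound 2 (0.15 log units; that floor lies within the scatter) and an at least 1.6-fold lower number from compound 2 to compound 3 (0.22 log units; that floor lies within the scatter). None is shown beyond the scatter, although the two involving compound 2 are floors only. Among the measured compounds shown here, no measured step changes a group on a sulfonyl sulfur, so these steps are only a loose guide. They give no ground for expecting a large move in this assay. The expected change is a 1.7-fold higher number from compound 3 to compound 4 (0.22 log units; within the scatter), a modest rise with wide uncertainty. Compound 4 is estimated at 10 mg/kg, with an expected range of 4 mg/kg to 30 mg/kg, and a reading that is only a limit remains quite possible.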

Compound 4, dose for half-maximal effect: > 10 mg/kg
Compound 4: only a limit was reported; the forecaster's own chance of this, stated with the estimate: 45%; the middle value sits exactly at the limit.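

This is the first change shown on the sulfonyl sulfur itself: in this assay, hydroxy in place of amino gives an at least 1.6-fold higher number from compound 3 to compound 4 (0.22 log units; that floor lies within the scatter), and the other readable step is an at least 1.4-fold higher number from compound 1 to compound 4 (0.15 log units; that floor lies within the scatter), so both are floors that lie within the scatter and no loss beyond it is established. The step between compound 2 and compound 4 cannot be read, as both compounds end in a limit. The side chains of compound 2 and compound 4 now share one ceiling, and it caps what this series can show: the limit of > 10 mg/kg in this assay, at which 2 of the 4 values shown sit.

The compounds shown leave open how far compound 4 lies past its limit, and so whether the change from amino to hydroxy matters at all in this assay. Also open, on these data alone, is how a methyl sulfone would read, or a carboxylic acid in place of the sulfo group.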